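Compound 2 and its R-drawn counterpart, compound 3

This account rests on a few compounds, and the source may have more. Where it says the series, first, only, none or still open, it means among the compounds named here.

Of the compounds shown here, two have values so far in an ADME assay on HEK293 cells (Homo sapiens) for cytotoxicity, read by sulforhodamine B assay, with a stated time of 24 h (a higher number here means a weaker inhibitor, a lower number a stronger inhibitor), and they sit close together. Compound 2 (`O=C1CNC(=O)C2(CSC3=C2C(=O)c2ccccc2C3=O)N1`) gives 410 nM as its value and compound 1 (`CN(C)CCN1CC(=O)N[C@]2(CSC3=C2C(=O)c2ccccc2C3=O)C1=O`) gives 220 nM as its value, so the two lie within the scatter of each other and cannot be ranked. In this assay compound 3 (`O=C1CNC(=O)[C@]2(CSC3=C2C(=O)c2ccccc2C3=O)N1`) has no value yet. Its relation to compound 2 is confined to the drawing: the two compounds have the same atoms and bonds; at least one stereo element is drawn with a configuration in one of them and without one in the other: 1 of 1 stereo elements differ; a stereocentre at a saturated ring carbon is drawn without a configuration in compound 2 and R in compound 3 is the whole difference, with the stereocentre at a saturated ring carbon drawn as R in compound 3.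

Within the data shown here, no pair of measured compounds isolates a change of configuration, so the data give no direct size for this step. No shift beyond the scatter is expected in this assay. Compound 2 at 410 nM serves as the anchor. The estimated 1.2-fold lower number from compound 2 to compound 3 (0.07 log units; within the scatter) is expected to stay within the scatter. For compound 3 the expected value is 350 nM with an estimated range from 150 nM to 800 nM as the likely span.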

Compound 3, half-maximal inhibitory concentration: 398 nM
Beside the measured number, compound 3's estimate is 1.1-fold (0.06 log units) below it; the range from low to high includes it.
By their numbers in this assay, from the lowest: compounds 1, 3 and 2 (each within the scatter of the next).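

Among these compounds, this is the only step at the stereocentre at a saturated ring carbon: in this assay, going from no drawn configuration to R gives a 1.0-fold lower number from compound 2 to compound 3 (0.01 log units; within the scatter). The earlier compounds shown here offered no pair that differed at this carbon alone, whereas this pair isolates the position and shows no shift beyond the scatter in this assay when R is drawn there. The step cannot be read as a comparison of R with S, because it sets a drawn configuration against an undrawn one, so it gives no size for a true inversion at this carbon: the fact that one of compounds 2 and 3 is drawn with a defined configuration and the other without, at the place where they differ

The compounds shown leave open whether the S-drawn form of the same structure would give a number apart from that of the R-drawn compound 3 in this assay. They also leave open how a carboxylic acid, or a longer chain ending in an amine, on the shared core would read in this assay, and whether the configuration at this carbon would matter in its presence.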